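A few compounds are considered here, and "the series" means these few. Any claim that something is new, unique, unknown or untested is made for them only; others in the source may bear on it.

Working notes on the series. In a physicochemical assay for acid dissociation, compound 1 (`NS(=O)(=O)c1ccc(SCCCO)c(Cl)c1`) gives 9.45 and compound 2 (`NS(=O)(=O)c1ccc(SCCCO)s1`) gives 9.32 and these two numbers lie within the usual scatter of each other. Going by the values given here, no pair of measured compounds differs in one place only, so the data offer no direct step to carry over.

Compound 3 (`NS(=O)(=O)c1ccc(SCCCCO)s1`) is not yet measured. It differs from compound 2 by a single change (hydroxymethyl in place of hydroxy on a saturated chain carbon, three bonds along the chain from a sulfur) with hydroxymethyl in place of hydroxy on a saturated chain carbon, three bonds along the chain from a sulfur. Cut one bond further out, the same difference reads 3-hydroxypropyl to 4-hydroxybutyl.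

No step beyond the scatter is expected in this assay for this change, in either direction. Among the compounds with values here, the expectation starts from compound 2 at 9.32 as the closest measured structure, with no measured step to refine it. The estimated a number 0.02 log units lower from compound 2 to compound 3 (within the scatter) stays within the scatter. The estimate for compound 3 is 9.3 with an expected range of (9.1 to 9.5).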

Compound 3, acid dissociation constant: 9.5
For compound 3 the middle estimate is 0.20 log units below the measured one; measured number inside the range.
By their numbers in this assay, from the lowest: compounds 2, 1 and 3 (each within the scatter of the next).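

In this assay, going by these compounds alone, hydroxymethyl in place of hydroxy on a saturated chain carbon, three bonds along the chain from a sulfur, gives a number 0.18 log units higher from compound 2 to compound 3 (within the scatter), and this is the first measured step between compounds that differ in one place only. For this single change, which also reads 3-hydroxypropyl to 4-hydroxybutyl, the read-out does not separate the two compounds, so the position now has one measured step where before there was only an estimate from the closest structure. No measured information on the origin of this step is at hand.

The step rests on one pair and one core, and whether it carries over to the core of compound 1 remains an open question. Also open, as far as these compounds go, is what a longer chain, an amine or a carboxylic acid in place of hydroxymethyl at this position would give in this assay, and whether any such group would produce a step beyond the scatter.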